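Diethylamino in Place of Amino at the Aromatic Carbon

The source may hold more compounds than are shown below. What is called first, only, known or untested is meant among the compounds shown, and "the series" means these compounds.

For the measured compounds named here, compound 2 `COc1ccc(/C=C/c2cc(OC)cc(OC)c2/C=C/C(=O)c2ccc(N)cc2)cc1` gives 3.8 ug/mL in a functional assay on A549 cells (Homo sapiens) for antiproliferative activity, read by MTT assay, with a stated time of 48 h (on this read-out lower numbers stand for stronger inhibition and higher numbers for weaker inhibition), the second highest of the three numbers measured so far. Compound 1 `CCCCOc1ccc(C(=O)/C=C/c2c(/C=C/c3ccc(OC)cc3)cc(OC)cc2OC)cc1` gives 8.7 ug/mL and compound 3 `COc1ccc(/C=C/c2cc(OC)cc(OC)c2/C=C/C(=O)c2ccc(C)c(C)c2)cc1` gives 0.1 ug/mL. Compound 4 `CCN(CC)c1ccc(C(=O)/C=C/c2c(/C=C/c3ccc(OC)cc3)cc(OC)cc2OC)cc1` differs from compound 2 by diethylamino in place of amino on an aromatic carbon. Going by the values given here, two measured steps touch the same aromatic carbon: a 2.3-fold lower number from compound 1 to compound 2 (0.36 log units; beyond the scatter), a modest shift, and a 38-fold lower number from compound 2 to compound 3 (1.58 log units; beyond the scatter), a large one, although neither exchanges amino for diethylamino. Among the compounds with values here, since the closest precedent a 2.3-fold lower number from compound 1 to compound 2 (0.36 log units; beyond the scatter) is only modest, the step from compound 2 is expected to be small, at most modest, and its direction is uncertain. Compound 4 is therefore expected to give 2.5 ug/mL, with a range from 0.6 ug/mL to 10 ug/mL, which means an expected step of a 1.5-fold lower number from compound 2 to compound 4 (0.18 log units; within the scatter).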

Compound 4, half-maximal inhibitory concentration: 5.4 ug/mL
The estimate for compound 4 lay 2.2-fold (0.33 log units) below the measured number, within the range that was stated.
By their numbers in this assay, from the lowest: compound 3; then compounds 2, 4 and 1 (each within the scatter of the next, the first and the last beyond it).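

In this assay, diethylamino in place of amino gives a 1.4-fold higher number from compound 2 to compound 4 (0.15 log units; within the scatter), and diethylamino in place of butoxy gives a 1.6-fold lower number from compound 1 to compound 4 (0.21 log units; within the scatter), so neither step at this aromatic carbon leaves the scatter. The 4-(diethylamino)phenyl group also leaves compound 4 far from the 3,4-dimethylphenyl compound, with a 54-fold higher number from compound 3 to compound 4 (1.73 log units; beyond the scatter), a gap as large as those seen with 4-aminophenyl and 4-butoxyphenyl. No measurement shown accounts for these numbers. The compounds shown leave open whether dimethylamino or a single methyl group on this aromatic carbon would bring the number close to that of compound 3.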